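Distal-ring substituent in the series: from hydroxy to sulfamoyl

The compounds below may be only part of what the source reports. "The series", "measured", "known", "first", "only" and "open" are said of these compounds alone.

Values in an assay on THP-1 cells for inhibition of nuclear factor NF-kappa-B complex (Homo sapiens), with stated times of 2 h and 16 h; on this read-out higher numbers stand for weaker inhibition and lower numbers for stronger inhibition:
compound 1 `CC(C)(C)CCOc1cccc(O)c1C(=O)/C=C/c1ccc(C(=O)O)cc1` — 2800 nM
compound 2 `CC(C)(C)CCOc1cccc(O)c1C(=O)/C=C/c1ccc(O)cc1` — 3000 nM
compound 3 `CC(C)=CCOc1cccc(O)c1C(=O)/C=C/c1ccc(O)cc1` — a limit of the assay, > 30000 nM

Compound 2 has the higher of the two numbers shown in this assay; the nearest is compound 1, whose step a 1.1-fold higher number from compound 1 to compound 2 (0.03 log units; within the scatter) stays within the scatter. For compound 3 only a limit is reported (the limit of > 30000 nM in this assay, at which 1 of the 3 values shown sits); the step of an at least 10-fold higher number from compound 2 to compound 3 (1.00 log units; beyond the scatter) is therefore at least as large as stated, and it concerns the chain on the oxygen of the shared core, not the distal ring.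

The new compound 4 `CC(C)(C)CCOc1cccc(O)c1C(=O)/C=C/c1ccc(S(N)(=O)=O)cc1` differs from compound 2 by sulfamoyl in place of hydroxy on an aromatic carbon. Within the data shown here, the only measured step at that place, a 1.1-fold higher number from compound 1 to compound 2 (0.03 log units; within the scatter), shows that exchanging the distal-ring group between hydroxy and carboxy leaves the number essentially unchanged. The step of an at least 10-fold higher number from compound 2 to compound 3 (1.00 log units; beyond the scatter) does not bear on this position. On this basis no step beyond the scatter is expected in this assay for the change to sulfamoyl, in either direction.

Compound 4 is therefore expected to give about 3000 nM in this assay, between 1000 nM and 10000 nM, an expected step of no change at the digits printed from compound 2 to compound 4 (within the scatter).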

Compound 4, half-maximal inhibitory concentration: 1200 nM
Compound 4: the middle estimate sits 2.5-fold (0.40 log units) above what was measured; the range from low to high includes it.
By their numbers in this assay, from the lowest: compound 4; then compounds 1 and 2 (each within the scatter of the next). At a limit, above all of these: compound 3.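

In this assay, the distal-ring position proves responsive to the group it carries: the step of a 2.5-fold lower number from compound 2 to compound 4 (0.40 log units; beyond the scatter) and the step of a 2.3-fold lower number from compound 1 to compound 4 (0.37 log units; beyond the scatter) both lie beyond the scatter, whereas the earlier exchange between hydroxy and carboxy at this place gave no step beyond it. Sulfamoyl is therefore tolerated on this aromatic carbon, para to a large group, and compound 4 has a modestly lower number than either compound 1 or compound 2, which remain within the scatter of each other. The data shown include no measurement that accounts for this modest difference.

Going by these compounds, it remains open whether the lower number depends on the nitrogen of sulfamoyl or on the sulfur-bearing part as a whole, a question that a methylsulfonyl group, a methylsulfamoyl group or a primary amine at the same place would help to address. Also open, on these data alone, is whether sulfamoyl gives a similar step on a core carrying the 2-methylprop-1-en-1-yl chain of compound 3, or with a longer chain on the oxygen of the shared core.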